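Replacing the Benzyl Group on the Amide Nitrogen with Hydroxyethyl

The source may report more compounds than this note shows. Statements on the series, on what has been measured and on what is new or still open speak of the compounds shown alone.

Measured compounds:
compound 1 `COc1cc2c(cc1OC)C(CC(N)=O)CC2` gives 24.6%
compound 2 `COc1cc2c(cc1OC)C(CC(=O)NC(C)(C)C)CC2` gives 41.8%
compound 3 `COc1cc2c(cc1OC)C(CC(=O)NCc1ccccc1)CC2` gives 48.1%

In a functional assay on the whole organism (strain Swiss albino) for inhibition, with Mus musculus as the target, in the writhing test, with stated times of 60 min and 15 min, at a dose of 100 mg/kg by the oral route (on this read-out higher numbers stand for more inhibition at the one dose given (going by the name of the read-out) and lower numbers for less inhibition), compound 3 holds the highest of the three numbers. Its distance from compound 1 is beyond the scatter, a number 23.5 percentage points higher from compound 1 to compound 3 (beyond the scatter), whereas its distance from compound 2 is within it, a number 6.3 percentage points higher from compound 2 to compound 3 (within the scatter), so compound 3 cannot be set apart from compound 2. Compound 4 `COc1cc2c(cc1OC)C(CC(=O)NCCO)CC2` differs from compound 3 by hydroxymethyl in place of phenyl on a saturated chain carbon bound to an amide-type nitrogen. The step of a number 23.5 percentage points higher from compound 1 to compound 3 (beyond the scatter) shows that the benzyl group on the amide nitrogen matters, while a number 6.3 percentage points higher from compound 2 to compound 3 (within the scatter) shows that tert-butyl in its place gives a number within the scatter of it. Within the data shown here, no measured step tells of hydroxymethyl in place of phenyl, so compound 4 is expected to lose part of the gain seen on going from hydrogen to benzyl. Compound 4 is estimated at 35%, between 20% and 50%, a step of a number 13.1 percentage points lower from compound 3 to compound 4 (beyond the scatter).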

Compound 4, a percentage reported as inhibition, in the whole organism at one dose (the size of the read-out at that dose, not a potency): 29.8%
Beside the measured number, compound 4's estimate is 5.2 percentage points above it; measured number inside the range.
By their numbers in this assay, from the lowest: compounds 1 and 4 (each within the scatter of the next); then compounds 2 and 3 (each within the scatter of the next).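

In this assay, hydroxymethyl in place of phenyl on a saturated chain carbon bound to an amide-type nitrogen gives up most of the gain seen with benzyl (a number 18.3 percentage points lower from compound 3 to compound 4 (beyond the scatter)), and 2-hydroxyethyl in place of tert-butyl also costs (a number 12 percentage points lower from compound 2 to compound 4 (beyond the scatter)). Against the amide hydrogen, 2-hydroxyethyl brings no gain that can be told apart (a number 5.2 percentage points higher from compound 1 to compound 4 (within the scatter)), so not every group on this nitrogen keeps the gain seen for compound 2 and compound 3. Nothing measured here accounts for this difference. On these data alone, whether an amine or a carboxylic acid in place of the hydroxyl of 2-hydroxyethyl, or a longer chain carrying the phenyl, would recover that gain stays open.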